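Acylation of the amino group on the shared core

The source may report more compounds than this note shows. Statements on the series, on what has been measured and on what is new or still open speak of the compounds shown alone.

Measured so far in an assay on CHO cells for displacement of a labelled ligand from adenosine receptor A1 (Homo sapiens), read by scintillation counting, with a stated time of 1 h, tested at 1 uM; on this read-out lower numbers stand for less inhibition and higher numbers for more inhibition at the one concentration tested (going by the name of the read-out):
compound 1, `Nc1ncc(-c2cccc(Cl)c2)c(-c2ccccc2)n1`: > 80%
compound 2, `COc1ccc(-c2cnc(N)nc2-c2ccccc2)cc1Cl`: > 80%
compound 3, `Nc1ncc(-c2ccc(O)c(Cl)c2)c(-c2ccccc2)n1`: > 80%

The value of compound 1 is a limit of the assay, not a number. The same holds for compound 2. The same holds for compound 3 (the limit of > 80% in this assay, at which 3 of the 3 values shown sit). Compound 1 therefore stands at the limit together with the other two. The steps a step that the two limits leave unreadable from compound 1 to compound 2, a step that the two limits leave unreadable from compound 1 to compound 3 and a step that the two limits leave unreadable from compound 2 to compound 3 all concern the chlorophenyl ring and none can be sized.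

Compound 4, `CCCC(=O)Nc1ncc(-c2cccc(Cl)c2)c(-c2ccccc2)n1`, differs from compound 1 by propylcarbonyl in place of hydrogen on a nitrogen on an aromatic ring. Going by the values given here, no measured step touches this nitrogen, so neither size nor direction can be read from the series, and any expectation is wide. Compound 4 is estimated at 55%, expected between 15% and 90%. The step from compound 1 to compound 4 implied by this estimate is a number at least 25 percentage points lower from compound 1 to compound 4 (beyond the scatter).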

Compound 4, a percentage reported as inhibition, at one concentration (the size of the read-out at that concentration, not a potency): > 80%
Compound 4: only a limit was reported; the forecaster's own chance of this, stated with the estimate: 30%; at least 25 percentage points between middle value and limit.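

Compound 1 and compound 4 both sit at a limit in this assay, so no step between them can be read: the limit of > 80% in this assay, at which 4 of the 4 values shown sit.

On these data alone, whether propylcarbonyl in place of hydrogen on the nitrogen changes inhibition at all stays open, as does any ranking of the four compounds.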